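Methyl for phenyl on the nitrogen-bound chain of compound 1

The source may report more compounds than this note shows. Statements on the series, on what has been measured and on what is new or still open speak of the compounds shown alone.

Measured compounds in an assay on HeLa cells for displacement of a labelled ligand from 5-hydroxytryptamine receptor 6 (Homo sapiens); on this read-out higher numbers stand for weaker inhibition and lower numbers for stronger inhibition:
compound 1 `CN1CCN(c2ccc3c(c2)c(S(=O)(=O)c2cccc4ccccc24)nn3Cc2ccccc2)CC1` gives 2 nM
compound 2 `O=S(=O)(c1ccc(Cl)cc1)c1n[nH]c2cccc(N3CCNCC3)c12` gives 125 nM

Compound 1 holds the lower of the two numbers in this assay; compound 2 lies far above it, beyond the scatter. Compound 3 `CCn1nc(S(=O)(=O)c2cccc3ccccc23)c2cc(N3CCN(C)CC3)ccc21` differs from compound 1 in one place: methyl in place of phenyl on a saturated chain carbon bound to an aromatic nitrogen. The same difference, cut one bond further out, reads benzyl to ethyl. Among the measured compounds shown here, no measured pair shows this change, so the expectation rests on compound 1 alone. A modest move toward weaker inhibition is expected, close to the edge of the scatter, as the step of a 2.5-fold higher number from compound 1 to compound 3 (0.40 log units; beyond the scatter). Compound 3 is therefore estimated at 5 nM, within 1 nM to 30 nM.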

Compound 3, inhibition constant: 1.7 nM
The estimate for compound 3 lay 2.9-fold (0.47 log units) above the measured number; low and high end bracket the measured number.
By their numbers in this assay, from the lowest: compounds 3 and 1 (each within the scatter of the next); then compound 2.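

In this assay, the change from benzyl to ethyl gives a 1.2-fold lower number from compound 1 to compound 3 (0.07 log units; within the scatter), which lies within the scatter, so the two compounds cannot be told apart. Among the compounds shown here, at this position, the phenyl ring and its six carbons are therefore not needed to keep the number in the range of compound 1, something the earlier compounds could not show. Nothing measured here accounts for this result.

Still open, from the compounds shown here alone, is how this position responds to other groups, such as a longer chain like butyl, an amine or a carboxylic acid at the end of the chain.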